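The source may report more compounds than this note shows. Statements on the series, on what has been measured and on what is new or still open speak of the compounds shown alone.

In an ADME assay on HepG2 2.2.15 cells (Homo sapiens) for cytotoxicity (a lower number here means that less compound is tolerated, a higher number that more compound is tolerated), three compounds sharing one core have been measured. Compound 1 `O=C(O)CCCC(=O)OCCc1c(-c2ccccc2Cl)c2cc(Cl)ccc2[nH]c1=O` gives 110000 nM, and compound 2 `O=C(/C=C/c1ccccc1)OCCc1c(-c2ccccc2Cl)c2cc(Cl)ccc2[nH]c1=O` gives 230000 nM. Compound 3 `O=C(/C=C/c1cccc(F)c1)OCCc1c(-c2ccccc2Cl)c2cc(Cl)ccc2[nH]c1=O` gives > 1600000 nM, which is a limit and not a number. Compound 3 is the best tolerated of the three: a 2.1-fold higher number from compound 1 to compound 2 (0.32 log units; beyond the scatter) is a modest step, an at least 14-fold higher number from compound 1 to compound 3 (1.16 log units; beyond the scatter) is a large one, and an at least 6.9-fold higher number from compound 2 to compound 3 (0.84 log units; beyond the scatter) is at least modest.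

Compound 4 `O=C(/C=C/c1cccc(C(F)(F)F)c1)OCCc1c(-c2ccccc2Cl)c2cc(Cl)ccc2[nH]c1=O` carries trifluoromethyl in place of the fluoro of compound 3, on an aromatic carbon meta to a large group: trifluoromethyl in place of fluoro on an aromatic carbon. Within the data shown here, no measured step makes this exact swap. The closest is an at least 6.9-fold higher number from compound 2 to compound 3 (0.84 log units; beyond the scatter), where fluoro replaces hydrogen on the same ring, so a change here can clearly shift the number. Among the measured compounds shown here, that step gives no direction for trifluoromethyl, but the only exact numbers lie much lower, with compound 2 at 230000 nM. A fall back towards that level therefore seems likely. The expected change is an at least 3.5-fold lower number from compound 3 to compound 4 (0.55 log units; beyond the scatter), a drop of at least modest size. For compound 4, the estimate is 450000 nM, with an expected range of 120000 nM to 1600000 nM.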

Compound 4, half-maximal cytotoxic concentration: > 1400000 nM
Compound 4: a limit, no number; the forecaster's own chance of this, stated with the estimate: 25%; middle value at least 3.1-fold (0.49 log units) away from the limit.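

In this assay, trifluoromethyl on this aromatic carbon, like the fluoro of compound 3, stands well clear of the ring that carries only hydrogen: there is an at least 6.0-fold higher number from compound 2 to compound 4 (0.78 log units; beyond the scatter), and also an at least 12-fold higher number from compound 1 to compound 4 (1.10 log units; beyond the scatter). The gain over hydrogen at this position is therefore not unique to fluoro, at least among these two groups. Compound 4 gives only a limit, as compound 3 does, so the step between them cannot be read and the two groups cannot be put in order: the limit of > 1400000 nM in this assay, at which 1 of the 4 values shown sits.

Going by these compounds, it remains open whether a group of another kind on the same carbon, such as an amine or a carboxylic acid, would keep the number this high. On these data alone, how far compound 3 and compound 4 truly lie beyond their limits also remains unknown.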